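A Single Chloro Removed From a Spiro Peroxide

The compounds below may be only part of what the source reports. "The series", "measured", "known", "first", "only" and "open" are said of these compounds alone.

Of the compounds shown here, three sharing a peroxide core have so far been tested in a functional assay on A549 cells (Homo sapiens) for inhibition, read by MTT assay, with a stated time of 72 h; on this read-out lower numbers stand for stronger inhibition and higher numbers for weaker inhibition. Compound 3 `C=C(c1ccc(Cl)c(Cl)c1Cl)C1COC2(CCCCC2)OO1` gives 1370 nM, the lower of the two numbers obtained. Compound 1 `C=C(c1ccc(F)c(F)c1)C1COC2(CCCC2)OO1` gives 11700 nM, a higher number, and the gap between these two lies beyond the usual scatter of repeated measurements. Compound 2 `C=C(c1ccc(F)c(F)c1)C1COC(C)(C)OO1` returns only a limit of this assay rather than a number, > 100000 nM (the limit of > 100000 nM in this assay, at which 1 of the 3 values shown sits).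

Compound 4 `C=C(c1ccc(Cl)cc1Cl)C1COC2(CCCCC2)OO1` has not yet been measured in this assay. It differs from compound 3 in one place: hydrogen in place of chloro on an aromatic carbon. Going by the values given here, no measured pair in this set isolates the effect of a single chloro on the aromatic ring, so the size of this step is open. Taking hydrogen in place of chloro on an aromatic carbon is expected to weaken inhibition modestly, giving an estimated step of a 2.2-fold higher number from compound 3 to compound 4 (0.34 log units; beyond the scatter). Compound 4 is therefore estimated at 3000 nM, with a likely range from 800 nM to 12000 nM.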

Compound 4, half-maximal inhibitory concentration: 810 nM
Compound 4: middle estimate off by 3.7-fold (0.57 log units), on the high side; measured number inside the range.
By their numbers in this assay, from the lowest: compounds 4 and 3 (each within the scatter of the next); then compound 1. At a limit, above all of these: compound 2.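

Going by these compounds alone, compound 3 and compound 4 form the first measured pair that isolates a single chloro on the aromatic ring, and in this assay the step is a 1.7-fold lower number from compound 3 to compound 4 (0.23 log units; within the scatter). At this place, ortho to two chloro groups and meta to a large group, hydrogen can therefore stand in for chloro with no difference this assay can tell apart, so this chloro is not needed for the inhibition seen with compound 3. Nothing measured here bears on how this result comes about.

The compounds shown leave open whether a methoxy group or an amine at this same place would also keep inhibition in this range, as only chloro and hydrogen are compared there. As far as these compounds go, it also remains open whether either of the two chloro groups left in compound 4 could be exchanged for hydrogen in the same way.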